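This account rests on a few compounds, and the source may have more. Where it says the series, first, only, none or still open, it means among the compounds named here.

Among the measured compounds shown here, in an ADME assay on microsomes from liver (Rattus norvegicus) for metabolic stability, read by LC-MS, using NADPH, with a stated time of 10 min, tested at 0.5 uM (a lower number here means that less of the compound is left, a higher number that more of the compound is left), three compounds have numbers so far: compound 1 (`CC(=O)Nc1cc(-c2cc(F)c(OC[C@@H](N)CC(C)C)c(F)c2)ccn1`) stands at 100% and compound 3 (`COC(=O)Nc1cc(-c2ccc(OC[C@@](C)(N)CC(C)C)c(C)c2C)ccn1`) at 83% while compound 2 (`COC(=O)Nc1cc(-c2cnc(OC[C@@](C)(N)CC(C)C)c(Cl)c2)ccn1`) stands at 73% of the compound left. Compound 2 thus lies within the usual scatter of compound 3, and its gap to compound 1, the higher of the two, goes beyond that scatter.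

Compound 4 (`COC(=O)Nc1cc(-c2cnc(OC[C@@](C)(N)CC(C)C)c(OC)c2)ccn1`) is compound 2 with methoxy in place of chloro on an aromatic carbon. The methoxy sits ortho to a (2-amino-2,4-dimethylpentyl)oxy group, two atoms from the ring nitrogen and meta to a large group.

For the measured compounds named here, no two measured compounds differ in one place only, so the data give no direct reading of this change. Compound 2 at 73% and compound 3 at 83% stay within the scatter of each other although they differ in more than one place, so no shift beyond the scatter is expected, even though compound 1 at 100% shows that wider gaps occur in this small set. The estimated change is a number 3 percentage points lower from compound 2 to compound 4 (within the scatter) and is expected to stay within the scatter. For compound 4 the expected value is 70% with an estimated range from 53% to 86% of the compound left.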

Compound 4, percent of the compound remaining: 79%
The estimate for compound 4 lay 9 percentage points below the measured number, within the range that was stated.
By their numbers in this assay, from the lowest: compounds 2, 4 and 3 (each within the scatter of the next); then compound 1.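

In this assay, among the compounds shown here, the exchange of chloro for methoxy gives a number 6 percentage points higher from compound 2 to compound 4 (within the scatter), and this is the first comparison in the set in which only one place differs. At this position, on an aromatic carbon ortho to a (2-amino-2,4-dimethylpentyl)oxy group, two atoms from the ring nitrogen and meta to a large group, the read-out therefore does not separate the two substituents, even though methoxy brings 2 heavy atoms where chloro has 1 and adds a hydrogen-bond acceptor. No measurement among these compounds offers an explanation for this result.

The compounds shown leave open whether a different group at this position, such as an amine, a nitrile or a longer chain like ethoxy, would also stay within the scatter of compound 2, since chloro and methoxy are the only two substituents compared here. They also leave open whether the same exchange would read the same way on the core of compound 1 or compound 3, as neither of these has a partner that differs from it in one place only.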